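The source may report more compounds than this note shows. Statements on the series, on what has been measured and on what is new or still open speak of the compounds shown alone.

Three compounds share one core and are compared in a functional assay on HCT-116 cells (Homo sapiens) for cytotoxicity, read by MTT assay, with a stated time of 48 h; on this read-out higher numbers stand for weaker inhibition and lower numbers for stronger inhibition. Compound 1 `CCN(CC)c1ccc2cc(C(=O)c3ccc(N4CCN(C(=O)CN5CCNCC5)CC4)cc3)oc2c1` carries a hydrogen on an amine nitrogen in a ring and gives 1870 nM. Compound 2 `CCN(CC)c1ccc2cc(C(=O)c3ccc(N4CCN(C(=O)CN5CCN(C(=O)/C=C/c6ccccc6)CC5)CC4)cc3)oc2c1` gives 6810 nM, and compound 3 `CCN(CC)c1ccc2cc(C(=O)c3ccc(N4CCN(C(=O)CN5CCN(S(=O)(=O)c6ccc(C#N)cc6)CC5)CC4)cc3)oc2c1` gives 36400 nM. Compound 2 therefore stands second highest of the three numbers: a 3.6-fold higher number from compound 1 to compound 2 (0.56 log units; beyond the scatter) and a 5.3-fold higher number from compound 2 to compound 3 (0.73 log units; beyond the scatter), both beyond the scatter; across the whole set, a 19-fold higher number from compound 1 to compound 3 (1.29 log units; beyond the scatter).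

Compound 4 `CCN(CC)c1ccc2cc(C(=O)c3ccc(N4CCN(C(=O)CN5CCN(Cc6ccc(C(F)(F)F)cc6)CC5)CC4)cc3)oc2c1` has not yet been measured. It differs from compound 2 in one place: 4-(trifluoromethyl)benzyl in place of (2-phenylethenyl)carbonyl on an amine nitrogen in a ring. Within the data shown here, the steps that bear on this are those in which the hydrogen of compound 1 was replaced by a larger group on that nitrogen, which raised the number modestly for the (2-phenylethenyl)carbonyl group and largely for the (4-cyanophenyl)sulfonyl group. Among the measured compounds shown here, no measured compound carries a benzyl group there, so the direction is uncertain; the entering group lacks the carbonyl, which separates it from both substituted cases, and a step toward the number of compound 1 is expected, a 1.9-fold lower number from compound 2 to compound 4 (0.29 log units; within the scatter), modest at most. Compound 4 is expected to give 3500 nM, estimated within 1200 nM to 10000 nM.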

Compound 4, half-maximal inhibitory concentration: > 40000 nM
Compound 4 gave a limit, no number; the forecaster's own chance of this, stated with the estimate: 3%; middle value at least 11-fold (1.05 log units) from the limit.
By their numbers in this assay, from the lowest: compound 1; then compound 2; then compound 3. At a limit, above all of these: compound 4.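

In this assay compound 4 gives a limit, not a number: the limit of > 40000 nM in this assay, at which 1 of the 4 values shown sits. With 4-(trifluoromethyl)benzyl in place of (2-phenylethenyl)carbonyl, the number did not move back toward that of the unsubstituted amine: there is an at least 5.8-fold higher number from compound 2 to compound 4 (0.76 log units; beyond the scatter). With 4-(trifluoromethyl)benzyl in place of hydrogen there is an at least 21-fold higher number from compound 1 to compound 4 (1.33 log units; beyond the scatter), so on this ring nitrogen the hydrogen of compound 1 remains the best of the four groups, and a carbonyl or sulfonyl link is not required for the weaker inhibition. With 4-(trifluoromethyl)benzyl in place of (4-cyanophenyl)sulfonyl there is an at least 1.0-fold higher number from compound 3 to compound 4 (0.04 log units; that floor lies within the scatter), and this step cannot be read.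

The compounds shown leave open whether the benzyl itself or its trifluoromethyl goes with this result, which a plain benzyl would separate. They also leave open how a group as small as methyl, or a chain ending in an amine, would compare with the hydrogen of compound 1.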